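From sec-butyl to tert-butyl: estimating compound 4

The source may report more compounds than this note shows. Statements on the series, on what has been measured and on what is new or still open speak of the compounds shown alone.

In a physicochemical assay for solubility, in phosphate buffer, at pH 6.5 (on this read-out lower numbers stand for lower solubility and higher numbers for higher solubility), compound 1 `C=C[C@@H]1C[C@]1(NC(=O)[C@@H]1C[C@@H](Oc2nccc3cc(OC)ccc23)CN1C(=O)[C@@H](NC(=O)N[C@@H](C)COC)C(C)(C)C)C(=O)NS(=O)(=O)C1CC1` gives 1070 ug/mL, compound 2 `C=C[C@@H]1C[C@]1(NC(=O)[C@@H]1C[C@@H](Oc2nccc3cc(OC)ccc23)CN1C(=O)[C@@H](NC(=O)N[C@@H](CC)COC)C(C)(C)C)C(=O)NS(=O)(=O)C1CC1` gives 500 ug/mL, and compound 3 `C=C[C@@H]1C[C@]1(NC(=O)[C@@H]1C[C@@H](Oc2nccc3cc(OC)ccc23)CN1C(=O)[C@@H](NC(=O)N[C@H](COC)[C@@H](C)CC)C(C)(C)C)C(=O)NS(=O)(=O)C1CC1` gives 326 ug/mL. Compound 3 thus stands clearly under compound 1 and within the scatter of compound 2.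

Compound 4 `C=C[C@@H]1C[C@]1(NC(=O)[C@@H]1C[C@@H](Oc2nccc3cc(OC)ccc23)CN1C(=O)[C@@H](NC(=O)N[C@H](COC)C(C)(C)C)C(C)(C)C)C(=O)NS(=O)(=O)C1CC1` has the same atoms as compound 3, joined differently: tert-butyl in place of sec-butyl on a saturated chain carbon bound to an amide-type nitrogen and a saturated chain carbon. It carries tert-butyl in place of sec-butyl on a saturated chain carbon bound to an amide-type nitrogen and a saturated chain carbon.

The measured steps at this place all added carbon: a 2.1-fold lower number from compound 1 to compound 2 (0.33 log units; beyond the scatter) and a 3.3-fold lower number from compound 1 to compound 3 (0.52 log units; beyond the scatter) were modest, and a 1.5-fold lower number from compound 2 to compound 3 (0.19 log units; within the scatter) stayed within the scatter. This change adds none, so no step beyond the scatter is expected. The estimated step is a 1.1-fold lower number from compound 3 to compound 4 (0.04 log units; within the scatter). Compound 4 is expected at 300 ug/mL, with an estimated range of 140 ug/mL to 650 ug/mL.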

Compound 4, solubility: 609 ug/mL
The estimate for compound 4 lay 2.0-fold (0.31 log units) below the measured number, within the range that was stated.
By their numbers in this assay, from the lowest: compounds 3, 2, 4 and 1 (each within the scatter of the next, the first and the last beyond it).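

Rearranging the same four carbons gives a 1.9-fold higher number from compound 3 to compound 4 (0.27 log units; within the scatter), and tert-butyl in place of ethyl gives a 1.2-fold higher number from compound 2 to compound 4 (0.09 log units; within the scatter), so neither step stands out from the scatter. Tert-butyl in place of methyl gives a 1.8-fold lower number from compound 1 to compound 4 (0.24 log units; within the scatter), whereas sec-butyl in place of methyl gave a step beyond the scatter, so the carbon count alone does not set the size of a step at this place. Nothing shown here explains why the two butyl groups differ in this way. Still open, from the compounds shown here alone, is how an amine or a carboxylic acid on this saturated chain carbon would read in this measurement.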